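The compounds below may be only part of what the source reports. "The series", "measured", "known", "first", "only" and "open" are said of these compounds alone.

In a functional assay on KB cells (Homo sapiens) for cytotoxicity, read by sulforhodamine B assay (on this read-out higher numbers stand for weaker inhibition and lower numbers for stronger inhibition), compound 3 `C=C1[C@@H](OC(C)=O)C[C@@H]2[C@](C)(COC=O)[C@H](OC(C)=O)CC[C@@]2(C)[C@@H]1C[C@@H](Nc1ccccc1)C1=CCOC1=O` gives 32100 nM. Among the three measured compounds it stands second highest: its nearest neighbour is compound 2 `C=C1[C@@H](OC(C)=O)C[C@@H]2[C@](C)(COC=O)[C@H](OC(C)=O)CC[C@@]2(C)[C@@H]1C[C@@H](Nc1cccc2ccccc12)C1=CCOC1=O`, which gives 32300 nM, and its furthest is compound 1 `C=C1[C@@H](OC(C)=O)C[C@@H]2[C@](C)(COC=O)[C@H](OC(C)=O)CC[C@@]2(C)[C@@H]1C[C@@H](Nc1ccc(Br)cc1)C1=CCOC1=O`, which gives 24000 nM, both gaps lying within the scatter. The step of a 1.0-fold lower number from compound 2 to compound 3 (0.00 log units; within the scatter) shows that exchanging the aryl group on the amine nitrogen leaves the read-out unmoved. Compound 4 `C=C1[C@@H](OC(C)=O)C[C@@H]2[C@](C)(COC=O)[C@H](OC(C)=O)CC[C@@]2(C)[C@@H]1C[C@@H](Nc1ccc(F)cc1)C1=CCOC1=O` differs from compound 3 by fluoro in place of hydrogen on an aromatic carbon. The measured step that bears on this change is a 1.3-fold higher number from compound 1 to compound 3 (0.13 log units; within the scatter), where a halogen left the same aromatic carbon without any shift beyond the scatter; the step of a 1.3-fold higher number from compound 1 to compound 2 (0.13 log units; within the scatter) points the same way. Compound 4 is therefore expected to show no step beyond the scatter, with a 1.1-fold lower number from compound 3 to compound 4 (0.06 log units; within the scatter) as the estimated change. The estimate for compound 4 in this assay is 28000 nM, with a range from 14000 nM to 56000 nM.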

Compound 4, half-maximal inhibitory concentration: 22900 nM
Estimate against measurement, compound 4: 1.2-fold (0.09 log units) above, and the stated range covers the measured number.
By their numbers in this assay, from the lowest: compounds 4, 1, 3 and 2 (each within the scatter of the next).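

Fluoro entering this aromatic carbon gives a 1.4-fold lower number from compound 3 to compound 4 (0.15 log units; within the scatter), so a group added at this place, and not only a halogen leaving it, stays within the scatter in this assay. Fluoro in place of bromo on the same carbon gives a 1.0-fold lower number from compound 1 to compound 4 (0.02 log units; within the scatter), and 4-fluorophenyl in place of naphthalen-1-yl on the amine nitrogen gives a 1.4-fold lower number from compound 2 to compound 4 (0.15 log units; within the scatter), so all the aryl groups shown on this nitrogen lie within the scatter of one another. Nothing at hand explains why these exchanges leave the read-out in place.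

The substituents shown on the phenyl ring are a hydrogen and two halogens, so it remains open whether a carboxylic acid, an amine or a methoxy group at this carbon would move the number beyond the scatter. As far as these compounds go, whether an alkyl chain on the nitrogen in place of the aryl group would do so also remains open.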